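This account rests on a few compounds, and the source may have more. Where it says the series, first, only, none or still open, it means among the compounds named here.

Working notes on the series.

Of the compounds shown here, three of the shared core have been measured in a functional assay on cells for antagonist activity at Free fatty acid receptor 1 (Homo sapiens), read by TR-FRET and inositol phosphate accumulation, with a stated time of 2 h; a lower number here means a stronger inhibitor, a higher number a weaker inhibitor. Compound 1 `CN(C)c1cc(COc2cccc(F)c2)nc(-c2ccccn2)n1` gives 1580 nM. Compound 2 `CC1(CS(C)(=O)=O)CN(c2cc(COc3ccc(F)c(F)c3F)nc(-c3ccccn3)n2)C1` gives 6310 nM. Among the compounds with values here, compound 3 `Fc1ccc(OCc2cc(OCC(F)(F)F)nc(-c3ccccn3)n2)c(F)c1F` gives 7.94 nM, the lowest of the three numbers; the values of compound 1 and compound 3 show compound 3 well beyond the scatter on the lower side, and the one single-point step recorded, a 790-fold lower number from compound 2 to compound 3 (2.90 log units; beyond the scatter), is large and separates compound 3 from compound 2 in the same sense.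

The next compound, compound 4 `Fc1ccc(OCc2cc(OCC3(F)COC3)nc(-c3ccccn3)n2)c(F)c1F`, differs from compound 3 in one place: 3-fluorooxetan-3-yl in place of trifluoromethyl on a saturated chain carbon bound to an oxygen on an aromatic ring. Within the data shown here, this change sits on the saturated chain carbon bound to an oxygen on an aromatic ring, whereas the only measured step, a 790-fold lower number from compound 2 to compound 3 (2.90 log units; beyond the scatter), concerned the exchange of the whole group on the aromatic carbon and does not address a swap within the 2,2,2-trifluoroethoxy itself. Among the measured compounds shown here, no measured step bears directly on this change. A moderate step in this assay is therefore expected, more likely toward a higher number than a lower one, though a result within the scatter of compound 3 cannot be excluded. For compound 4 the step expected is a 3.1-fold higher number from compound 3 to compound 4 (0.50 log units; beyond the scatter). Compound 4 is accordingly estimated at 25 nM, with a range from 6 nM to 100 nM.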

Compound 4, half-maximal inhibitory concentration: 63.1 nM
Compound 4: the middle estimate sits 2.5-fold (0.40 log units) below what was measured; the measured number falls inside the stated range.
By their numbers in this assay, from the lowest: compound 3; then compound 4; then compound 1; then compound 2.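

In this assay, within the data shown here, the change from trifluoromethyl to 3-fluorooxetan-3-yl on the saturated chain carbon bound to an oxygen on an aromatic ring gives a 7.9-fold higher number from compound 3 to compound 4 (0.90 log units; beyond the scatter), the first evidence that the number responds to a change at this position and not only to exchange of the whole group on the aromatic carbon. The response is modest, whereas (3-fluorooxetan-3-yl)methoxy in place of 3-methyl-3-((methylsulfonyl)methyl)azetidin-1-yl gives a 100-fold lower number from compound 2 to compound 4 (2.00 log units; beyond the scatter), so compound 4, like compound 3, stands far below compound 2 and the step to a ring-bearing group on this chain does not remove that large gain. No measurement at hand accounts for the higher number of compound 4 relative to compound 3.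

The compounds shown leave open whether the step follows from the ring, its oxygen or the change in fluorine count, a question that a plain oxetan-3-yl or a fluorocyclobutyl group on the same chain would help to separate. They also leave open how the number responds to a longer chain or to an amine at this position.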